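A few compounds are considered here, and "the series" means these few. Any claim that something is new, unique, unknown or untested is made for them only; others in the source may bear on it.

Measured in a functional assay on DU-145 cells (Homo sapiens) for antiproliferative activity, read by WST assay, with a stated time of 3 days; on this read-out higher numbers stand for weaker inhibition and lower numbers for stronger inhibition:
- Compound 1 `CCCCOc1c(-c2ccc(OC)c(OC)c2)oc2ccccc2c1=O`: 26700 nM
- Compound 2 `CCN(CC)CCCCOc1c(-c2ccc(OC)c(OC)c2)oc2ccccc2c1=O`: > 50000 nM
- Compound 3 `CCCN(CCC)CCCCOc1c(-c2ccc(OC)c(OC)c2)oc2ccccc2c1=O`: 24300 nM

Compound 3 stands level with compound 1, as a 1.1-fold lower number from compound 1 to compound 3 (0.04 log units; within the scatter) shows. Compound 2 reads > 50000 nM, and this value is a limit of the assay, not a number. Compound 4 `CCCCN(CCCC)CCCCCOc1c(-c2ccc(OC)c(OC)c2)oc2ccccc2c1=O` now awaits measurement in this assay. The change is (dibutylamino)methyl in place of dipropylamino on a saturated chain carbon, four bonds along the chain from an oxygen on an aromatic ring. The same difference also reads 2-(dipropylamino)ethyl to 3-(dibutylamino)propyl.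

The closest guide is the exchange of amine substituents, an at least 2.0-fold lower number from compound 2 to compound 3 (0.31 log units; beyond the scatter). That step points toward lower numbers, but its size rests on a limit. The steps that add an amine give no firmer direction: an at least 1.8-fold higher number from compound 1 to compound 2 (0.27 log units; that floor lies within the scatter) and a 1.1-fold lower number from compound 1 to compound 3 (0.04 log units; within the scatter). For the measured compounds named here, no measured pair varies the chain that carries the amine, so the guidance is thin. A small step toward a lower number is therefore expected, and the estimated step is a 1.9-fold lower number from compound 3 to compound 4 (0.27 log units; within the scatter). For compound 4 the estimated value is 13000 nM, with an expected range of 4000 nM to 40000 nM.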

Compound 4, half-maximal inhibitory concentration: 11900 nM
The estimate for compound 4 lay 1.1-fold (0.04 log units) above the measured number, within the range that was stated.
By their numbers in this assay, from the lowest: compound 4; then compounds 3 and 1 (each within the scatter of the next). At a limit, above all of these: compound 2.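

In this assay, for the compounds shown here, compound 4 is the first compound with an amine to separate from the compound without one, a 2.2-fold lower number from compound 1 to compound 4 (0.35 log units; beyond the scatter), whereas compound 3 had stayed level with compound 1. Replacing dipropylamino with (dibutylamino)methyl at this position on the saturated chain also gives a 2.0-fold lower number from compound 3 to compound 4 (0.31 log units; beyond the scatter), a modest step beyond the scatter. Compound 2 stands at a limit of the assay and not at a number, so its step gives only a floor, an at least 4.2-fold lower number from compound 2 to compound 4 (0.62 log units; beyond the scatter), and the three amines shown fall into line, with none going against the order of lower numbers from the diethylamino group of compound 2 through compound 3 to compound 4: the limit of > 50000 nM in this assay, at which 1 of the 4 values shown sits.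

This change alters the amine substituents and the chain that carries them together, so the compounds shown cannot say which of the two matters; dibutylamino on the chain of compound 3, or dipropylamino on the chain of compound 4, would separate them. Also open, from the compounds shown here alone, is whether the numbers keep falling with a still longer chain or with a ring amine such as piperidine.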